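This account rests on a few compounds, and the source may have more. Where it says the series, first, only, none or still open, it means among the compounds named here.

compound 1 `CC(=O)N(C(C)=O)c1ccc(-c2nc3ccccc3s2)cc1`: > 100 nM
compound 2 `O=C(CCl)Nc1ccc(-c2nc3ccccc3s2)cc1`: > 100 nM
compound 3 `O=C(Nc1ccc(-c2nc3ccccc3s2)cc1)C(Cl)Cl`: > 100 nM

In a functional assay on MDA-MB-468 cells (Homo sapiens) for antiproliferative activity (a lower number here means a stronger inhibitor, a higher number a weaker inhibitor), compound 3 stands at > 100 nM, which is a limit of the assay and not a number. All three measured compounds sit at this same limit: the limit of > 100 nM in this assay, at which 3 of the 3 values shown sit. Compound 4 `O=C(Nc1ccc(-c2nc3ccccc3s2)cc1)c1ccccc1` carries phenyl in place of dichloromethyl on a carbonyl carbon. The closest guide is a step that the two limits leave unreadable from compound 2 to compound 3, and a step that the two limits leave unreadable from compound 1 to compound 2 and a step that the two limits leave unreadable from compound 1 to compound 3 add no size either. None of these steps shows a size or a direction, so no clear move is expected in this assay, and the result may again be only a limit. The expected change is a step that the limit leaves unreadable from compound 3 to compound 4. Compound 4 is estimated at 150 nM, with an expected range of 40 nM to 1000 nM.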

Compound 4, half-maximal inhibitory concentration: > 1000 nM
Compound 4 ended at the assay's limit; the forecaster's own chance of this, stated with the estimate: 70%; middle value at least 6.6-fold (0.82 log units) away from the limit.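

No new step can be read: compound 2, compound 3 and compound 4 all carry limits of the assay, not numbers. The compounds shown leave open how strongly any of them acts in this assay.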